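The compounds below may be only part of what the source reports. "The series", "measured", "known", "first", "only" and "open" are said of these compounds alone.

Of the compounds shown here, two with a shared core have been measured in an ADME assay on cells (Hepatocyte, Homo sapiens), with a stated time of 60 min; a lower number here means that less of the compound is left, a higher number that more of the compound is left. Compound 1 `O=C1CCC(=O)N1Cc1cc2nccc(-c3cc(Cl)cc4c3O[C@@H](c3onc5c3CNCC5)C4)c2s1` gives 26% in this assay. Compound 2 `O=C1CCC(=O)N1Cc1cc2nccc(-c3cc(Cl)cc4c3O[C@@H](c3ocnc3CN3CCC3)C4)c2s1` gives 14% in this assay. The only difference between them is the group on a saturated ring carbon of the core, and this change gave a number 12 percentage points lower from compound 1 to compound 2 (beyond the scatter). Compound 2 thus stands lowest of the two numbers, below compound 1 by a step beyond the scatter.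

Compound 3 `Cn1nc2c(c1[C@H]1Cc3cc(Cl)cc(-c4ccnc5cc(CN6C(=O)CCC6=O)sc45)c3O1)CNCC2` has not yet been measured. Compared with compound 2, the change is a group of 10 heavy atoms (7 carbon, 3 nitrogen; one five-membered aromatic ring with 2 hetero atoms, one six-membered non-aromatic ring with 1 hetero atom) in place of a group of 10 heavy atoms (7 carbon, 2 nitrogen, 1 oxygen; one four-membered non-aromatic ring with 1 hetero atom, one five-membered aromatic ring with 2 hetero atoms), on a saturated ring carbon. The group that enters carries a six-membered non-aromatic ring with one hetero atom, as does the group in compound 1, so the measured step bears on it, though only in part, since the five-membered aromatic ring also differs. That measured step, a number 12 percentage points lower from compound 1 to compound 2 (beyond the scatter), was modest. A step of similar size in the opposite direction, a number 9 percentage points higher from compound 2 to compound 3 (within the scatter), is expected, landing near compound 1. Compound 3 is therefore estimated at 23%, with a range from 10% to 38%.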

Compound 3, percent of the compound remaining: 63%
The estimate for compound 3 lay 40 percentage points below the measured number, and the stated range ends below it.
By their numbers in this assay, from the lowest: compound 2; then compound 1; then compound 3.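

The group on the saturated ring carbon next to the ring oxygen can shift the number in this assay far more than the first pair suggested: the result is a number 49 percentage points higher from compound 2 to compound 3 (beyond the scatter), and also a number 37 percentage points higher from compound 1 to compound 3 (beyond the scatter). The six-membered non-aromatic ring with one hetero atom does not settle the outcome by itself, since both compound 1 and compound 3 carry it, so the rest of the group, including the five-membered aromatic ring, matters here as well. Among these three compounds, the group with three nitrogens and no oxygen stands above both oxygen-containing groups, but no measurement shown here explains this rise.

As far as these compounds go, the change from compound 1 to compound 3 alters the aromatic ring and adds a methyl group at once, so the share of each in the rise remains open. Also open, from the compounds shown here alone, is whether an ethyl group in place of that methyl, or a dimethylaminomethyl group in place of the six-membered non-aromatic ring, would keep as much of the compound in this assay.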